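From trifluoromethyl to methoxy: estimating compound 3

This account rests on a few compounds, and the source may have more. Where it says the series, first, only, none or still open, it means among the compounds named here.

In a functional assay on HeLa cells (Homo sapiens) for inhibition, read by sulforhodamine B assay (a higher number here means a weaker inhibitor, a lower number a stronger inhibitor), compound 1 `O=C1C=C(Nc2ccccc2F)C(=O)c2c1nc1n2[C@H]2OC[C@@H](O)[C@H]2OC1` gives 5120 nM. Compound 2 `O=C1C=C(Nc2ccc(C(F)(F)F)cc2)C(=O)c2c1nc1n2[C@H]2OC[C@@H](O)[C@H]2OC1` gives > 8000 nM, which is a limit of the assay and not a number. Its true position is therefore open.

Compound 3 `COc1ccc(NC2=CC(=O)c3nc4n(c3C2=O)[C@H]2OC[C@@H](O)[C@H]2OC4)cc1` keeps the shared core and changes one group, with 4-(trifluoromethyl)phenyl becoming 4-methoxyphenyl: methoxy in place of trifluoromethyl on an aromatic carbon.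

Within the data shown here, only one measured step bears on this change, and it does so indirectly: an at least 1.5-fold higher number from compound 1 to compound 2 (0.19 log units; that floor lies within the scatter). That step also involves the 4-(trifluoromethyl)phenyl group, but it exchanges this group for 2-fluorophenyl and says nothing directly about methoxy. Its size cannot be told apart from the scatter, so it gives no reason to expect a clear move in either direction. Among the measured compounds shown here, the best anchor is compound 1 at 5120 nM, the only true number so far, and a step beyond the scatter is not expected in this assay.

The expected step is an at least 1.3-fold lower number from compound 2 to compound 3 (0.12 log units; that floor lies within the scatter). For compound 3, the estimated value is 6000 nM, within an expected range from 2500 nM to 14000 nM.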

Compound 3, half-maximal inhibitory concentration: 4780 nM
Estimate against measurement, compound 3: 1.3-fold (0.10 log units) above; the range from low to high includes it.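

Methoxy in place of trifluoromethyl on this aromatic carbon gives an at least 1.6-fold lower number from compound 2 to compound 3 (0.22 log units; that floor lies within the scatter), so the 4-substituted ring now has a true number in this assay, but the step itself is only a floor. Going by these compounds, compound 2 remains a limit and not a number, so the real size of this step stays unknown: the limit of > 8000 nM in this assay, at which 1 of the 3 values shown sits. The firmer comparison is with the 2-fluorophenyl compound, which shows a 1.1-fold lower number from compound 1 to compound 3 (0.03 log units; within the scatter), so 2-fluorophenyl and 4-methoxyphenyl on the amine nitrogen cannot be told apart here, and the second true number adds no evidence that the choice between these two groups matters.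

No step shown is printed as beyond the scatter, so it remains open whether any group at this position can clearly move the number in this assay, and whether 4-(trifluoromethyl)phenyl truly differs from the other two. A carboxylic acid or an amine on the aromatic ring, or a longer carbon chain on the amine nitrogen in place of the ring, would be a wider test of this position.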